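A few compounds are considered here, and "the series" means these few. Any claim that something is new, unique, unknown or untested is made for them only; others in the source may bear on it.

Measured compounds:
compound 1 `OC1CCCN(c2nc(-c3ccccn3)nc3c2CN(Cc2ccccc2)CC3)C1`: 2800 nM
compound 2 `NC(=O)C1CCN(c2nc(-c3ccccn3)nc3c2CN(Cc2ccccc2)CC3)CC1`: 1400 nM
compound 3 `NC(=O)CN1CCN(c2nc(-c3ccccn3)nc3c2CN(Cc2ccccc2)CC3)CC1`: 2800 nM

In an assay on FRT cells with Cystic fibrosis transmembrane conductance regulator variant F508del (Homo sapiens) as the target, read by fluorescence, with a stated time of 25 min (on this read-out lower numbers stand for an effect already at smaller amounts and higher numbers for an effect only at larger amounts of compound), compound 3 gives 2800 nM. It stands at the same number as compound 1 and within the scatter of compound 2; none of the three is separated from another beyond the scatter. The steps among them all concern the amine substituent on the same aromatic carbon: a 2.0-fold lower number from compound 1 to compound 2 (0.30 log units; within the scatter), no change at the digits printed from compound 1 to compound 3 (within the scatter) and a 2.0-fold higher number from compound 2 to compound 3 (0.30 log units; within the scatter).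

Compound 4 `CN1CCN(CCCNc2nc(-c3ccccn3)nc3c2CN(Cc2ccccc2)CC3)CC1` differs from compound 3 by (3-(4-methylpiperazin-1-yl)propyl)amino in place of 4-(carbamoylmethyl)piperazin-1-yl on an aromatic carbon. The three measured steps bear on it in that each exchanges the substituent at this aromatic carbon, and each stayed within the scatter. None of them, however, replaces a directly attached six-membered ring by an amino-linked propyl chain carrying the ring, so the measured steps cover only part of this change. On that footing no step beyond the scatter is expected in this assay, but with a wide range, and the expected step from compound 3 to compound 4 is no change at the digits printed from compound 3 to compound 4 (within the scatter). Compound 4 is therefore estimated at 2800 nM, between 700 nM and 11000 nM.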

Compound 4, half-maximal effective concentration: 3100 nM
Compound 4: middle estimate off by 1.1-fold (0.04 log units), on the low side, and the stated range covers the measured number.
By their numbers in this assay, from the lowest: compounds 2, 1, 3 and 4 (each within the scatter of the next, the first and the last beyond it).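

In this assay, the substituent on this aromatic carbon can carry its six-membered ring at the end of an amino-linked propyl chain rather than directly attached, with the number staying within the scatter in two of the three comparisons (a 1.1-fold higher number from compound 3 to compound 4 (0.04 log units; within the scatter); a 1.1-fold higher number from compound 1 to compound 4 (0.04 log units; within the scatter)). The oxygen present in the substituents of compounds 1, 2 and 3 is absent from (3-(4-methylpiperazin-1-yl)propyl)amino, yet only the comparison with the 4-carbamoylpiperidin-1-yl group separates beyond the scatter, and modestly (a 2.2-fold higher number from compound 2 to compound 4 (0.35 log units; beyond the scatter)); compound 1 and compound 3 do not share that separation. Nothing available here accounts for these steps.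

Still open, as far as these compounds go, is how the number depends on the propyl chain itself, as an ethyl or butyl chain between the amino group and the piperazine would show. Also open, from the compounds shown here alone, is whether the terminal methyl of compound 4 can give way to a carbamoylmethyl group or a carboxylic acid on the same chain, and whether a morpholine can stand in place of the piperazine.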